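The source may hold more compounds than are shown below. What is called first, only, known or untested is meant among the compounds shown, and "the series" means these compounds.

Measured in a functional assay on U-251 cells (Homo sapiens); a higher number here means a weaker inhibitor of growth, a lower number a stronger inhibitor of growth:
- Compound 1 `O=S(=O)(/C=C/c1ccccc1)Cc1ccc(Nc2ncnc3ccccc23)cc1`: > 100000 nM, a limit of the assay and not a number
- Compound 2 `O=S(=O)(/C=C/c1ccc(F)cc1)Cc1ccc(Nc2ncnc3ccccc23)cc1`: 10 nM

In this assay, for the measured compounds named here, compound 2 holds the only actual number so far, 10 nM. For compound 1 there is only > 100000 nM, which is a limit of the assay. Compound 3 `N#Cc1ccc(/C=C/S(=O)(=O)Cc2ccc(Nc3ncnc4ccccc34)cc2)cc1` follows from compound 2 by one change, cyano in place of fluoro on an aromatic carbon, para to a large group.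

Going by the values given here, one measured step bears on this carbon, an at least 10000-fold lower number from compound 1 to compound 2 (4.00 log units; beyond the scatter), where fluoro took the place of hydrogen. That step is large and well beyond the scatter, so a substituent at this place can matter greatly, at least in this single pair. It does not show how cyano will compare with fluoro. With compound 2 already at 10 nM, a moderate rise in the number is expected, though a much larger one cannot be excluded. The expected size is a 6.0-fold higher number from compound 2 to compound 3 (0.78 log units; beyond the scatter). For compound 3 the estimated value is 60 nM, with an expected range from 5 nM to 10000 nM.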

Compound 3, concentration for 50% growth inhibition: > 100000 nM
Compound 3 was reported as a limit; the forecaster's own chance of this, stated with the estimate: 15%; middle value at least 1600-fold (3.22 log units) away from the limit.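

Cyano in place of fluoro on this aromatic carbon, para to a large group, gave in this assay an at least 10000-fold higher number from compound 2 to compound 3 (4.00 log units; beyond the scatter). The earlier pair showed only that this carbon can matter, whereas this step shows that replacing hydrogen here is not enough in itself: the outcome depends on which group is placed there, and compound 2, with fluoro, is the only one of the three with an actual number rather than a limit of the assay: the limit of > 100000 nM in this assay, at which 2 of the 3 values shown sit.

The step from compound 1 to compound 3 cannot be read, as both ends of it are limits, so hydrogen and cyano cannot be ordered against each other.

With only hydrogen, fluoro and cyano shown at this carbon, it remains open whether chloro, methoxy or an amine would stay close to compound 2 or would also reach the limit. On these data alone, it also remains open whether the sharp difference belongs to fluoro alone, as a single measured number cannot show how far this result extends to other groups.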